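The source may hold more compounds than are shown below. What is called first, only, known or untested is meant among the compounds shown, and "the series" means these compounds.

Measured in a functional assay on cells (Homo sapiens) for antiproliferative activity, read by MTT assay, with a stated time of 48 h; on this read-out higher numbers stand for weaker inhibition and lower numbers for stronger inhibition:
Compound 1 `CCN(CC)CCCCn1c(N)c(-c2nc3ccccc3[nH]2)c2nc(C#N)c(C#N)nc21`: 640 nM
Compound 2 `CCN(CC)CCn1c(N)c(-c2nc3cc(Cl)ccc3[nH]2)c2nc(C#N)c(C#N)nc21`: > 50000 nM, a limit of the assay

Compound 2 stands at a limit and not at a number, with > 50000 nM in this assay. Compound 3 `CCN(CC)CCCCn1c(N)c(-c2nc3cc(Cl)ccc3[nH]2)c2nc(C#N)c(C#N)nc21` differs from compound 2 by one change: 2-(diethylamino)ethyl in place of diethylamino on a saturated chain carbon, two bonds along the chain from an aromatic nitrogen. This gives compound 3 the 4-(diethylamino)butyl chain also carried by compound 1, and compound 1 gives 640 nM. A large step towards stronger inhibition in this assay is therefore expected, estimated as an at least 50-fold lower number from compound 2 to compound 3 (1.69 log units; beyond the scatter). Compound 3 is expected at 1000 nM, with an estimated range of 250 nM to 6000 nM.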

Compound 3, half-maximal inhibitory concentration: 2840 nM
For compound 3 the middle estimate is 2.8-fold (0.45 log units) below the measured one, and the stated range covers the measured number.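

In this assay, a 4-(diethylamino)butyl chain in place of a 2-(diethylamino)ethyl chain gives an at least 17-fold lower number from compound 2 to compound 3 (1.24 log units; beyond the scatter). That step is only a bound, since compound 2 stands at a limit and not at a number: the limit of > 50000 nM in this assay, at which 1 of the 3 values shown sits.

With the chain held, chloro in place of hydrogen on an aromatic carbon gives a 4.4-fold higher number from compound 1 to compound 3 (0.65 log units; beyond the scatter), a modest step beside the large one for the chain. The compounds shown leave open how a 3-(diethylamino)propyl chain or a longer chain would read, and whether fluoro or methoxy in place of chloro would give a different number.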